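The source may report more compounds than this note shows. Statements on the series, on what has been measured and on what is new or still open speak of the compounds shown alone.

Compound 1 `Fc1ccc(/N=C/c2ccccc2Cl)cc1Cl` stands at the lowest number of the two compounds measured in a functional assay on CCRF-CEM cells (Homo sapiens), read by cell counting, with a stated time of 72 h; a lower number here means a stronger inhibitor, a higher number a weaker inhibitor: in this assay compound 1 gives 10 ug/mL. Among the compounds with values here, the only other measured compound, compound 2 `Fc1ccc(/C=C/c2ccccc2F)cc1`, gives 83 ug/mL in this assay, a number far enough from that of compound 1 to lie beyond the usual scatter. Within the data shown here, no step between these two has been worked out, since they differ from each other in several places at once.

Compound 3 `Fc1ccc(/N=C/c2ccccc2Cl)cc1` is compound 1 with a single change: hydrogen in place of chloro on an aromatic carbon. Among the measured compounds shown here, no pair of measured compounds shows the effect of this change on its own, so the size of the step is open. Removing the chloro group is expected to weaken inhibition somewhat, with a 2.5-fold higher number from compound 1 to compound 3 (0.40 log units; beyond the scatter) estimated as a rise that reaches beyond the scatter. Compound 3 is therefore expected to give about 25 ug/mL in this assay, within a range of 8 ug/mL to 70 ug/mL.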

Compound 3, half-maximal inhibitory concentration: 2.1 ug/mL
Estimate against measurement, compound 3: 12-fold (1.08 log units) above; the whole stated range lies above it.
By their numbers in this assay, from the lowest: compound 3; then compound 1; then compound 2.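

Replacing the chloro group with hydrogen on this aromatic carbon, ortho to a fluoro group, strengthens inhibition in this assay, with a 4.8-fold lower number from compound 1 to compound 3 (0.68 log units; beyond the scatter). The chloro group at this position is therefore not required for inhibition in this assay, something the two earlier compounds could not show, as they differ in several places at once. Nothing measured here accounts for the size or direction of this step.

This single pair leaves open how other groups on the same carbon, such as a methoxy group, an amine or a nitrile, would compare with hydrogen. It also leaves open whether the same change would give a step of similar size and direction in a compound with a different group at the other end of the molecule.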